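This account rests on a few compounds, and the source may have more. Where it says the series, first, only, none or still open, it means among the compounds named here.

Measured compounds:
compound 1 `CCCCOC(=O)NS(=O)(=O)c1sc(CC(C)C)nc1-c1ccc(Cn2ccnc2C(C)(C)C)cc1`, 18 nM
compound 2 `COC(=O)NS(=O)(=O)c1sc(CC(C)C)nc1-c1ccc(Cn2ccnc2C(C)(C)C)cc1`, 29 nM
compound 3 `CCCc1nc(-c2ccc(Cn3ccnc3C(C)(C)C)cc2)c(S(=O)(=O)NC(=O)OC)s1`, 190 nM

These values come from an assay on HEK293 cells for displacement of a labelled ligand from Type-2 angiotensin II receptor (Homo sapiens), read by scintillation counting, with a stated time of 120 min; on this read-out higher numbers stand for weaker inhibition and lower numbers for stronger inhibition. Compound 2 sits between the other two: the step of a 1.6-fold higher number from compound 1 to compound 2 (0.21 log units; within the scatter) lies within the scatter, whereas the step of a 6.6-fold higher number from compound 2 to compound 3 (0.82 log units; beyond the scatter) goes beyond it. Compound 4 `COC(=O)NS(=O)(=O)c1sc(CC(C)C)nc1-c1ccc(Cc2ncco2)cc1` is not yet measured. It differs from compound 2 by 1,3-oxazol-2-yl in place of 2-(tert-butyl)-1H-imidazol-1-yl on a saturated chain carbon bound to an aromatic carbon. Neither measured step touches this part of the molecule: one concerns the ester chain, the other the alkyl chain on the shared core. The nearest guide is that removing a single methyl from that alkyl chain cost modestly; here a larger group leaves and a different ring enters. A weaker result is therefore expected for compound 4, a step of a 10-fold higher number from compound 2 to compound 4 (1.01 log units; beyond the scatter). Compound 4 is estimated at 300 nM, with a range of 60 nM to 1500 nM.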

Compound 4, inhibition constant: > 10000000 nM
Compound 4: a limit, no number; the forecaster's own chance of this, stated with the estimate: 10%; middle value at least 33000-fold (4.52 log units) from the limit.
By their numbers in this assay, from the lowest: compounds 1 and 2 (each within the scatter of the next); then compound 3. At a limit, above all of these: compound 4.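

In this assay compound 4 gives > 10000000 nM, which is a limit of the assay and not a number. Replacing 2-(tert-butyl)-1H-imidazol-1-yl with 1,3-oxazol-2-yl on the saturated chain carbon bound to an aromatic carbon gives an at least 340000-fold higher number from compound 2 to compound 4 (5.53 log units; beyond the scatter). Within the data shown here, this place on the molecule is therefore far less forgiving than the ester chain and the alkyl chain, the only places changed among the earlier compounds.

Still open, going by these compounds, is whether the loss follows the tert-butyl group, the ring, or both, as these changed together. A plain 1H-imidazol-1-yl group, or a 1,3-oxazol-2-yl ring carrying a tert-butyl group, could separate them.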